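The source may hold more compounds than are shown below. What is called first, only, known or untested is meant among the compounds shown, and "the series" means these compounds.

Measured compounds in the series:

compound 1, `Nc1nn(COCCO)c2nnc(-c3ccccc3)c(-c3ccccc3)c12` — > 100000 nM
compound 2, `Nc1[nH]nc2nnc(-c3ccco3)c(-c3ccco3)c12` — "not determined" (no result reported)
compound 3, `NNc1[nH]nc2nnc(-c3ccccc3)c(-c3ccccc3)c12` — "not determined" (no result reported)

In a functional assay on PC-3 cells (Homo sapiens) for cytotoxicity (on this read-out lower numbers stand for stronger inhibition and higher numbers for weaker inhibition), compound 1 returns only a limit, > 100000 nM, not a number. For compound 2 and compound 3 no result was reported in this assay. Compound 1 therefore stands alone on the numbers shown, and it stands at the limit of > 100000 nM in this assay, at which 1 of the 3 values shown sits. Within the data shown here, no step between two measured compounds can be read from this set.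

Compound 4, `CC(=O)n1nc(N)c2c(-c3ccccc3)c(-c3ccccc3)nnc21`, is the next compound in line for this assay. It differs from compound 1 in one place: acetyl in place of (2-hydroxyethoxy)methyl on an aromatic nitrogen. With compound 1 giving > 100000 nM, the step from compound 1 to compound 4 is expected to be a number no higher from compound 1 to compound 4 (the limit leaves the size open), that is, no change that would rise above the usual scatter of this assay. Compound 4 is accordingly expected to sit at about 100000 nM, with a plausible spread from 30000 nM to 300000 nM, and a real chance that this assay again reports only a limit for compound 4 rather than a number.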

Compound 4, half-maximal inhibitory concentration: > 100000 nM
Compound 4 ended at the assay's limit (the forecaster's own chance of this, stated with the estimate: 65%); the middle value sits exactly at the limit.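

Among these compounds, compound 1 and compound 4 each return only a limit, not a number, and no step between them can be read. The compounds shown leave open whether acetyl and (2-hydroxyethoxy)methyl on the aromatic nitrogen differ at all in this assay, and whether any group there would give a number.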